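Furan to thiophene exchange on the shared core

A few compounds are considered here, and "the series" means these few. Any claim that something is new, unique, unknown or untested is made for them only; others in the source may bear on it.

Compound 3 `CC1=C(C(=O)OC(C)C)C(c2ccoc2)NC(=S)N1` gives 23% in an assay on HeLa cells for displacement of a labelled ligand from adenosine receptor A3 (Homo sapiens), with a stated time of 180 min, tested at 10 uM; on this read-out lower numbers stand for less inhibition and higher numbers for more inhibition at the one concentration tested (going by the name of the read-out). That is the highest of the three numbers in hand, but the footing is uneven: compound 2 `CCOC(=O)C1=C(C)NC(=S)NC1c1ccoc1` gives 15%, and the gap from there to compound 3 lies within the scatter, while compound 1 `CCOC(=O)C1=C(c2ccccc2)NC(=O)NC1c1ccco1` gives 2%, a gap that lies beyond it. Compound 1 differs from the other two in several places at once, so its number shows only that it sits lower. Going by the values given here, the one step with a single change is a number 8 percentage points higher from compound 2 to compound 3 (within the scatter); it concerns the ester and not the aromatic ring.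

Compound 4 `CC1=C(C(=O)OC(C)C)C(c2ccsc2)NC(=S)N1` carries thiophen-3-yl in place of furan-3-yl on a saturated ring carbon. Among the compounds with values here, no measured step touches the aromatic ring or exchanges an oxygen for a sulfur, so nothing measured bears directly on this change; the ester step says only that one small change left the number within the scatter. Compound 4 is therefore expected to move by a number 2 percentage points higher from compound 3 to compound 4 (within the scatter), which is not beyond the scatter. Compound 4 is estimated to give 25% in this assay, with a range from 8% to 45%.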

Compound 4, a percentage reported as inhibition, at one concentration (the size of the read-out at that concentration, not a potency): 3%
Estimate against measurement, compound 4: 22 percentage points above; measured number below the stated range.
By their numbers in this assay, from the lowest: compounds 1 and 4 (each within the scatter of the next); then compounds 2 and 3 (each within the scatter of the next).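

In this assay, the exchange of furan-3-yl for thiophen-3-yl on the saturated ring carbon gives a number 20 percentage points lower from compound 3 to compound 4 (beyond the scatter) and is the only single change shown that goes beyond the scatter, which marks this position as one where the read-out responds to the aromatic group. The two groups match in their heavy-atom and hydrogen-bond counts and differ only in oxygen against sulfur, so the exchange of that one ring atom is enough for a step of this size on the shared core. Nothing at hand accounts for the drop.

On these data alone, it remains open whether a pyridin-3-yl or a cyclopentyl group on this carbon would read like furan-3-yl or like thiophen-3-yl, and whether the same exchange gives a similar step with the ethyl ester of compound 2 in place of the isopropoxycarbonyl group. All these numbers come from one concentration, so the step says nothing about potency.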